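Pyrimidinyl Amide Tested Against Cytotoxic Liver-Cell Read-Out

The source may report more compounds than this note shows. Statements on the series, on what has been measured and on what is new or still open speak of the compounds shown alone.

Two compounds from one series have so far been examined in a toxicity assay on HepG2 cells (Homo sapiens) for inhibition, read by CellTiter-Glo, with a stated time of 48 h; on this read-out lower numbers stand for stronger inhibition and higher numbers for weaker inhibition. Among the measured compounds shown here, compound 1, `COc1ccc2nc(C(F)(F)F)cc(OCC(=O)Nc3cc(C)cc(C)c3)c2c1`, is the first of them. In this assay compound 1 reaches only the limit of the assay, > 100000 nM, so no finished number exists for it. That value of compound 1 is the limit of > 100000 nM in this assay, at which 1 of the 2 values shown sits. Compound 2, `COc1ccc2nc(C)cc(OCC(=O)Nc3ccccc3)c2c1`, is the second. In this assay, for the measured compounds named here, compound 2 gives 39800 nM, which is the only actual number in the set. Compound 3, `COc1ccc2nc(C)cc(OCC(=O)Nc3ccncn3)c2c1`, has not yet been measured. It differs from compound 2 in a single place: pyrimidin-4-yl in place of phenyl on an amide-type nitrogen. Going by the values given here, no two measured compounds share this change. Among the compounds with values here, there is no measured step to lean on, and any expectation rests on compound 2 alone. The change is expected to leave the read-out about where compound 2 sits or to shift it toward weaker inhibition, a step of a 1.5-fold higher number from compound 2 to compound 3 (0.18 log units; within the scatter) that need not exceed the usual scatter, with a fair chance that the assay again reports only its limit. Compound 3 is therefore estimated at 60000 nM, within a range from 20000 nM to 100000 nM.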

Compound 3, half-maximal inhibitory concentration: > 100000 nM
Compound 3: a limit, no number (the forecaster's own chance of this, stated with the estimate: 45%); middle value at least 1.6-fold (0.22 log units) from the limit.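

Among the compounds shown here, the change from phenyl to pyrimidin-4-yl on the amide-type nitrogen gives an at least 2.5-fold higher number from compound 2 to compound 3 (0.40 log units; beyond the scatter) in this assay, the first single-place step, and it runs toward weaker inhibition. In this assay compound 3 gives > 100000 nM and this is a limit of the assay, not a number, so the step has a lower bound but no exact size. For the compounds shown here, the group on this nitrogen therefore affects the read-out, and the change moves compound 3 away from the only actual number in the set and onto the limit shared by most of the series: the limit of > 100000 nM in this assay, at which 2 of the 3 values shown sit.

This single pair leaves open whether the same change would act alike on a core carrying trifluoromethyl, as in compound 1, and whether a pyridin-3-yl ring, a cyclohexyl ring or a simple methyl group on the amide-type nitrogen would stay near compound 2 or also reach the limit. It also leaves open whether an amine or a carboxylic acid on the phenyl ring of compound 2 would move the read-out toward stronger inhibition.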